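Ethylsulfonyl in place of sec-butyl: expected cytotoxicity

The source may hold more compounds than are shown below. What is called first, only, known or untested is meant among the compounds shown, and "the series" means these compounds.

Two compounds have so far been tested in an ADME assay on MT4 cells (Homo sapiens) for cytotoxicity, read by MTT assay, with a stated time of 5 days; a lower number here means that less compound is tolerated, a higher number that more compound is tolerated:
Compound 1 `CCCCN(c1ccnc(Nc2ccc(C#N)cc2)n1)c1c(F)cc(-c2ccc(C#N)cc2)cc1F` gives 211000 nM.
Compound 2 `CCC(C)N(c1ccnc(Nc2ccc(C#N)cc2)n1)c1c(F)cc(-c2ccc(C#N)cc2)cc1F` gives 217000 nM.

For the measured compounds named here, compound 2 holds the higher of the two numbers, but its only neighbour is compound 1, and the step of a 1.0-fold higher number from compound 1 to compound 2 (0.01 log units; within the scatter) lies within the scatter, so the two compounds cannot be told apart in this assay. Compound 3 `CCS(=O)(=O)N(c1ccnc(Nc2ccc(C#N)cc2)n1)c1c(F)cc(-c2ccc(C#N)cc2)cc1F` is the next compound, differing from compound 2 by ethylsulfonyl in place of sec-butyl on a nitrogen on an aromatic ring.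

Going by the values given here, the single measured step, a 1.0-fold higher number from compound 1 to compound 2 (0.01 log units; within the scatter), exchanged one alkyl chain for another and left the number unmoved. Among the compounds with values here, no measured pair shows an ethylsulfonyl entering where sec-butyl leaves, so that step bears on compound 3 only loosely. With nothing pointing either way, the expectation for compound 3 in this assay is no step beyond the scatter, held with a wide range.

Compound 3 is therefore estimated at 210000 nM, between 80000 nM and 500000 nM. That estimate means an expected step of a 1.0-fold lower number from compound 2 to compound 3 (0.01 log units; within the scatter).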

Compound 3, half-maximal cytotoxic concentration: > 125000 nM
Compound 3 was reported as a limit; the forecaster's own chance of this, stated with the estimate: 25%; the middle value is on the limit's open side.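

Compound 3 is reported only as a limit, > 125000 nM. The steps from compound 1 and from compound 2 to compound 3 cannot be read. The compounds shown leave open whether ethylsulfonyl in place of butyl or sec-butyl on that nitrogen changes the tolerated concentration at all, or in which direction.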